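Adding a (2-chlorophenoxy)methyl group to a nitrofuran amide

A few compounds are considered here, and "the series" means these few. Any claim that something is new, unique, unknown or untested is made for them only; others in the source may bear on it.

Measured compounds:
compound 1 `CC(C)(NC(=O)c1ccc([N+](=O)[O-])o1)c1ccccc1`, > 180000 nM
compound 2 `O=C(NC1(c2ccccc2)CC1)c1ccc([N+](=O)[O-])o1`, 46000 nM
compound 3 `CC(C)(C)C(NC(=O)c1ccc([N+](=O)[O-])o1)c1ccccc1`, 10000 nM

These three compounds share a nitrofuran amide core and were tested in an ADME assay on Vero cells (Chlorocebus sabaeus) for cytotoxicity, read by MTT assay, with a stated time of 48 h; a higher number here means that more compound is tolerated, a lower number that less compound is tolerated. In this assay compound 1 gives > 180000 nM, which is a limit of the assay and not a number. Compound 2 gives 46000 nM, and compound 3 gives 10000 nM. Compound 1 thus stands at the limit of > 180000 nM in this assay, at which 1 of the 3 values shown sits, while the other two values are numbers that lie below that limit.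

The new compound 4 `CC(C)(NC(=O)c1ccc([N+](=O)[O-])o1)c1ccc(COc2ccccc2Cl)cc1` differs from compound 1 in one place: (2-chlorophenoxy)methyl in place of hydrogen on an aromatic carbon. Among the measured compounds shown here, no pair of measured compounds differs in exactly this way, so the size of the change can only be guessed. The step of an at least 3.6-fold lower number from compound 1 to compound 4 (0.55 log units; beyond the scatter) is expected to go toward a less tolerated compound, with a size beyond the scatter. Compound 4 is therefore estimated at 50000 nM, with a range from 15000 nM to 180000 nM.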

Compound 4, half-maximal cytotoxic concentration: 30000 nM
Compound 4: the middle estimate sits 1.7-fold (0.22 log units) above what was measured, and the stated range covers the measured number.
By their numbers in this assay, from the lowest: compound 3; then compounds 4 and 2 (each within the scatter of the next). At a limit, above all of these: compound 1.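

Putting (2-chlorophenoxy)methyl in place of hydrogen on an aromatic carbon, para to a large group, gives in this assay an at least 6.0-fold lower number from compound 1 to compound 4 (0.77 log units; beyond the scatter). Among the compounds shown here, the earlier compounds carry no group on this ring, so this is the first sign that a change at this position can alter how much compound the cells tolerate. The true size of the step may be larger, because compound 1 sits at a limit of the assay and not at a number: the limit of > 180000 nM in this assay, at which 1 of the 4 values shown sits.

For the compounds shown here, with only one group at this position, it remains open whether the drop goes with the chlorine, the ether oxygen or the added ring. A plain methyl, a methoxy or an unchlorinated phenoxymethyl at the same place could separate these, and an amine or a carboxylic acid there would test a quite different kind of group.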